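Removing the nitro group from the sulfonyl aryl of compound 1

A few compounds are considered here, and "the series" means these few. Any claim that something is new, unique, unknown or untested is made for them only; others in the source may bear on it.

Measured compounds in this series:
compound 1 `CC(=O)c1ccc(NC(=O)C(CC(C)C)N(C(=O)c2ccccc2)S(=O)(=O)c2ccc([N+](=O)[O-])cc2)cc1` — 62.3%
compound 2 `CC(=O)c1ccc(NC(=O)C(C(C)C)N(C(=O)c2ccccc2)S(=O)(=O)c2ccc([N+](=O)[O-])cc2)cc1` — 29.8%

In a functional assay for inhibition, read by spectrophotometry, with a stated time of 20 min, tested at 3 mg/mL (a lower number here means a weaker effect, a higher number a stronger effect of the compound at the concentration tested), compound 1 gives 62.3%, the higher of the two numbers recorded. Compound 2 gives 29.8%. Among the compounds with values here, the only measured step between them is a number 32.5 percentage points lower from compound 1 to compound 2 (beyond the scatter), and it concerns isopropyl in place of isobutyl on a saturated chain carbon bound to an amide-type nitrogen and a carbonyl carbon, a part of the molecule that compound 3 leaves untouched.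

Compound 3 `CC(=O)c1ccc(NC(=O)C(CC(C)C)N(C(=O)c2ccccc2)S(=O)(=O)c2ccccc2)cc1` differs from compound 1 elsewhere: hydrogen in place of nitro on an aromatic carbon. Read one bond further out, this is (4-nitrophenyl)sulfonyl becoming phenylsulfonyl. Within the data shown here, no measured step in this set changes that aryl, so the step from compound 1 to compound 2 does not bear directly on it, and nothing here tells how large a change to expect. The most cautious expectation is a step of a number 12.3 percentage points lower from compound 1 to compound 3 (beyond the scatter) in this assay, with a wide range on either side.

Compound 3 is therefore estimated to give about 50%, between 22% and 75%.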

Compound 3, a percentage reported as inhibition, at one concentration (the size of the read-out at that concentration, not a potency): 40.7%
The estimate for compound 3 lay 9.3 percentage points above the measured number; the measured number falls inside the stated range.
By their numbers in this assay, from the lowest: compound 2; then compound 3; then compound 1.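

In this assay, replacing nitro with hydrogen gives a number 21.6 percentage points lower from compound 1 to compound 3 (beyond the scatter), which makes the sulfonyl aryl a second place in the molecule, after the isobutyl-bearing chain carbon, where a single change moves the number beyond the scatter. Compound 3 still gives 40.7%, so the effect seen at the concentration tested does not rest on the nitro group alone, although the nitro-bearing compound 1 reads higher at 62.3%. Nothing available speaks to why the number falls when nitro leaves this aromatic carbon.

With only nitro and hydrogen shown at this place, it remains open whether an amine, a methoxy group, a chlorine atom or a carboxylic acid on the same aromatic carbon would bring the number back towards that of compound 1, leave it near that of compound 3 or take it elsewhere. The compounds shown also leave open whether the same exchange of nitro for hydrogen would produce a similar step on the isopropyl chain of compound 2.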